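The source may hold more compounds than are shown below. What is called first, only, known or untested is meant among the compounds shown, and "the series" means these compounds.

Compound 1 `CC/C=C\C/C=C\C/C=C\CCCCCCCc1cc(=O)c2c(O)c(C)c(O)cc2o1` carries a long chain with three double bonds on a core that is itself part of a ring system. In a functional assay on MCF7 cells (Homo sapiens) for antiproliferative activity, read by MTT assay (a higher number here means a weaker inhibitor, a lower number a stronger inhibitor), compound 1 gives 17500 nM. Compound 2 `CCCCC/C=C\C/C=C\CCCCCCCc1cc(=O)c2c(O)c(C)c(O)cc2o1` differs from compound 1 by butyl in place of but-1-en-1-yl on a saturated chain carbon bound to a double-bonded chain carbon. For compound 2 this assay reports only a limit, > 84100 nM, which is the limit of > 84100 nM in this assay, at which 1 of the 3 values shown sits. The step is therefore an at least 4.8-fold higher number from compound 1 to compound 2 (0.68 log units; beyond the scatter), so removing one double bond at that position weakened the inhibition of cell growth by a clear margin.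

Compound 3 `CC/C=C\C/C=C\C/C=C\CCCCCCCC1(O)CC(=O)c2c(O)cc(O)cc2O1` has the same three-double-bond chain as compound 1 on a different core; how the two cores differ is not broken down here. In this assay compound 3 gives 17500 nM, level with compound 1 at the digits printed.

Compound 4 `CCCCC/C=C\C/C=C\CCCCCCCC1(O)CC(=O)c2c(O)cc(O)cc2O1` has not yet been measured. Among the compounds with values here, it differs from compound 3 by butyl in place of but-1-en-1-yl on a saturated chain carbon bound to a double-bonded chain carbon, the same change, at the same place, as the one that took compound 1 to compound 2. Since compound 3 sits at 17500 nM, just as compound 1 does, and since the earlier step was an at least 4.8-fold higher number from compound 1 to compound 2 (0.68 log units; beyond the scatter), the step from compound 3 to compound 4 is expected to be a 5.1-fold higher number from compound 3 to compound 4 (0.71 log units; beyond the scatter). On that basis compound 4 is estimated to give 90000 nM, with a range from 30000 nM to 300000 nM, and there is a fair chance that this assay again reports only a limit.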

Compound 4, half-maximal inhibitory concentration: 17500 nM
Compound 4: the middle estimate sits 5.1-fold (0.71 log units) above what was measured; the measured number lies below the stated range.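

In this assay, putting butyl in place of but-1-en-1-yl on the core of compound 3 gives no change at the digits printed from compound 3 to compound 4 (within the scatter), so the change that weakened inhibition on the core of compound 1 leaves the read-out in place here, and its result does not carry over from one core to the other: the same change on two cores in this assay, an at least 4.8-fold higher number (0.68 log units; beyond the scatter) from compound 1 to compound 2 and no change at the digits printed (within the scatter) from compound 3 to compound 4, at least 4.8-fold (0.68 log units) apart, beyond the scatter of two such steps.
For compound 2 the value of > 84100 nM is a limit of the assay and not a number: the limit of > 84100 nM in this assay, at which 1 of the 4 values shown sits.
The comparison rests on a single pair of compounds on each core, so it shows that the outcome of this change can differ with the core, but it does not show which part of the two cores makes the difference, nor that the same split would appear on any further core.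

The compounds shown leave open how the chain itself matters on either core, for example whether a fully saturated chain or a shorter or longer chain would shift the read-out. They also leave open whether a carboxylic acid or an amine at the far end of the chain would bring the two cores into line or set them further apart.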